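The compounds below may be only part of what the source reports. "The series", "measured", "known", "first", "only" and "open" are said of these compounds alone.

Working notes on the series built on the shared core of compound 1 `Nc1ccccc1NC(=O)c1ccc(NC(=S)NCc2cccc(F)c2)cc1`. In an assay on isolated protein for inhibition of Nicotinamide phosphoribosyltransferase (Homo sapiens), read by fluorescence, with stated times of 5 min and 15 min (on this read-out higher numbers stand for weaker inhibition and lower numbers for stronger inhibition), compound 1 gives > 2000 nM, which is a limit of the assay and not a number. Compound 2 `Nc1ccccc1NC(=O)c1ccc(NC(=S)NCc2cccc(Cl)c2)cc1` gives in this assay > 2000 nM, likewise a limit. Compound 3 `Nc1ccccc1NC(=O)c1ccc(NC(=O)NCc2ccc(Cl)nc2)cc1` gives in this assay > 2000 nM, again a limit. The measured step that the two limits leave unreadable from compound 2 to compound 1 corresponds to the change (fluoro in place of chloro on an aromatic carbon). How the core of compound 3 differs from that of compound 2 is not broken down here. Compound 4 `Nc1ccccc1NC(=O)c1ccc(NC(=O)NCc2ccc(F)nc2)cc1` carries the same kind of change, (fluoro in place of chloro on an aromatic carbon); here the ring holds one nitrogen and the group sits next to the ring nitrogen, para to a large group, whereas in compound 1 the ring is of carbon only and the group is meta to a large group. Because the limit of > 2000 nM in this assay, at which 3 of the 3 values shown sit, the step is expected to be a step that the limit leaves unreadable from compound 3 to compound 4, read off the earlier pair rather than any resolved trend. Compound 4 is estimated at 3000 nM, between 1500 nM and 20000 nM.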

Compound 4, half-maximal inhibitory concentration: > 2000 nM
Compound 4: no number, only a limit (the forecaster's own chance of this, stated with the estimate: 80%); the middle value lies beyond the limit too.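

No step can be read from compound 3 to compound 4, as both give only a limit of the assay: the limit of > 2000 nM in this assay, at which 4 of the 4 values shown sit. In this assay the compounds shown leave open how far any of them inhibits, and whether fluoro in place of chloro changes that.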